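The source may report more compounds than this note shows. Statements on the series, on what has been measured and on what is new or still open speak of the compounds shown alone.

Compound 1 `CCCCCCC(=O)OCc1ccc2oc(=O)c(C(=O)Oc3cccc(Br)c3)cc2c1` and compound 2 `CC(C)(C)C(=O)OCc1ccc2oc(=O)c(C(=O)Oc3cccc(Br)c3)cc2c1` differ only in the group on the carbonyl carbon. In a functional assay on HT-1080 cells (Homo sapiens), read by transwell migration, with a stated time of 24 h, tested at 0.1 uM (a lower number here means a stronger effect, a higher number a weaker effect of the compound at the concentration tested), compound 1 gives 89.4%, whereas compound 2 gives 65.2%, the lowest of the two numbers, and the step of a number 24.2 percentage points lower from compound 1 to compound 2 (beyond the scatter) lies beyond the scatter. Compound 3 `CC(=O)NCc1ccc2oc(=O)c(C(=O)Oc3cccc(Br)c3)cc2c1` differs from compound 2 in one place: acetamido in place of ((tert-butyl)carbonyl)oxy on a saturated chain carbon bound to an aromatic carbon. For the measured compounds named here, none of the measured steps touches an acetamido group, so the single step to compound 2 is the only guide. The expected step of a number 6.8 percentage points higher from compound 2 to compound 3 (within the scatter) is therefore small and uncertain. Compound 3 is expected to give 72%, between 48% and 96%.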

Compound 3, a percentage reported as activity, at one concentration (the size of the read-out at that concentration, not a potency): 34.4%
Compound 3: middle estimate off by 37.6 percentage points, on the high side; measured number outside the range, below it.
By their numbers in this assay, from the lowest: compound 3; then compound 2; then compound 1.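

The earlier pair varied only the group on the carbonyl carbon, whereas here the whole ((tert-butyl)carbonyl)oxy group gives way to acetamido on the saturated chain carbon. In this assay this exchange gives a number 30.8 percentage points lower from compound 2 to compound 3 (beyond the scatter) and is also seen against the hexyl compound, as a number 55 percentage points lower from compound 1 to compound 3 (beyond the scatter) in this series. The compounds shown offer no measurement that explains these steps.

As far as these compounds go, it remains open whether the amide hydrogen is needed, which an N-methyl acetamido group could test. A free amine or a longer acyl chain on the nitrogen could also show how far this trend extends.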